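Triazole-linked ureas: from a 3-ethylphenyl to a 2-iodophenyl

This account rests on a few compounds, and the source may have more. Where it says the series, first, only, none or still open, it means among the compounds named here.

Compound 1 `COc1ccc(-n2cc(COc3cccc(NC(=O)Nc4ccc(Cl)c(C(F)(F)F)c4)c3)nn2)cc1`: 4680 nM
Compound 2 `CCc1ccccc1-n1cc(COc2cccc(NC(=O)Nc3ccc(Cl)c(C(F)(F)F)c3)c2)nn1`: 3530 nM
Compound 3 `CCc1cccc(-n2cc(COc3cccc(NC(=O)Nc4ccc(Cl)c(C(F)(F)F)c4)c3)nn2)c1`: 37900 nM

These three compounds were tested in a functional assay on HepG2 cells (Homo sapiens) for inhibition, read by MTT assay, with a stated time of 72 h; on this read-out higher numbers stand for weaker inhibition and lower numbers for stronger inhibition. Compound 3 gives the highest number of the three; its closest neighbour is compound 1, as an 8.1-fold higher number from compound 1 to compound 3 (0.91 log units; beyond the scatter) shows, and the widest gap is to compound 2, as an 11-fold higher number from compound 2 to compound 3 (1.03 log units; beyond the scatter) shows. Both gaps lie beyond the scatter, so compound 3 is the weakest inhibitor among those measured.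

Compound 4 `O=C(Nc1cccc(OCc2cn(-c3ccccc3I)nn2)c1)Nc1ccc(Cl)c(C(F)(F)F)c1` has not yet been measured. Relative to compound 3 the change is 2-iodophenyl in place of 3-ethylphenyl on an aromatic nitrogen. The step that bears most on it is an 11-fold higher number from compound 2 to compound 3 (1.03 log units; beyond the scatter), a large rise when the ethyl group moved from the 2-ethylphenyl of compound 2 to the 3-ethylphenyl of compound 3; an 8.1-fold higher number from compound 1 to compound 3 (0.91 log units; beyond the scatter) points the same way. Since compound 4 carries a 2-iodophenyl, the expectation is that this rise is largely undone, giving a large drop, a 7.6-fold lower number from compound 3 to compound 4 (0.88 log units; beyond the scatter). Compound 4 is therefore estimated at 5000 nM in this assay, within a range from 1500 nM to 20000 nM.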

Compound 4, half-maximal inhibitory concentration: 2870 nM
Compound 4: middle estimate off by 1.7-fold (0.24 log units), on the high side, and the stated range covers the measured number.
By their numbers in this assay, from the lowest: compounds 4, 2 and 1 (each within the scatter of the next); then compound 3.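

In (this assay), putting 2-iodophenyl in place of 3-ethylphenyl gives a large change (a 13-fold lower number from compound 3 to compound 4 (1.12 log units; beyond the scatter)). Iodo in place of ethyl leaves the number within the scatter (a 1.2-fold lower number from compound 2 to compound 4 (0.09 log units; within the scatter)), so two quite different groups in the 2-substituted phenyl give results that cannot be told apart. The 4-methoxyphenyl also cannot be separated from the 2-iodophenyl (a 1.6-fold lower number from compound 1 to compound 4 (0.21 log units; within the scatter)), which leaves the 3-ethylphenyl of compound 3 as the one clear outlier among these four compounds.

No measurement shown here explains this gap. On these data alone, it remains open whether a 3-iodophenyl would also give a high number, and whether a 2-aminophenyl or a 2-carboxyphenyl would stay level with the 2-iodophenyl.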